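Swapping methyl for trifluoromethyl on a sulfur-linked benzyl group

The compounds below may be only part of what the source reports. "The series", "measured", "known", "first", "only" and "open" are said of these compounds alone.

Compound 1 `Cc1cccc(CSc2cc(Cl)c(C)cc2S(=O)(=O)/N=C(\N)n2nccc2-c2ccccc2)c1` is one of three close relatives studied in an ADME assay on microsomes from liver (Homo sapiens) for metabolic stability, read by LC-MS, using NADPH, tested at 5 uM (a lower number here means that the compound disappears faster, a higher number that the compound lasts longer), where compound 1 gives 0.232 h. Compound 2 `Cc1cc(-c2ccccc2)n(/C(N)=N/S(=O)(=O)c2cc(C)c(Cl)cc2SCc2cccc3ccccc23)n1` gives 0.256 h in this assay, and compound 3 `Cc1cc(-c2ccccc2)n(/C(N)=N/S(=O)(=O)c2cc(C)c(Cl)cc2SCc2ccccc2C)n1` gives 0.154 h. All three numbers lie within the usual scatter of repeated measurements of one another, so none of them can be told apart from the rest on these data alone.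

Compound 4 `Cc1cc(S(=O)(=O)/N=C(\N)n2nccc2-c2ccccc2)c(SCc2cccc(C(F)(F)F)c2)cc1Cl` is reached from compound 1 by one change: trifluoromethyl in place of methyl on an aromatic carbon. Among the compounds with values here, no measured pair shows exactly this exchange. Within the data shown here, the only step available sits on the same sulfur-linked benzyl group, where a different exchange gave a 1.7-fold lower number from compound 2 to compound 3 (0.22 log units; within the scatter), a change too small to count. Among the measured compounds shown here, that is the only guidance, and it points to no movement beyond the scatter.

For compound 4 the half-life in this assay is therefore estimated at 0.25 h, expected to lie between 0.12 h and 0.5 h. This amounts to an expected step of a 1.1-fold higher number from compound 1 to compound 4 (0.03 log units; within the scatter), which is no real change from the starting point.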

Compound 4, half-life: 0.0863 h
Compound 4: the middle estimate sits 2.9-fold (0.46 log units) above what was measured; the whole stated range lies above it.
By their numbers in this assay, from the lowest: compounds 4, 3, 1 and 2 (each within the scatter of the next, the first and the last beyond it).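

Unlike the earlier step on the sulfur-linked benzyl group, which stayed within the scatter, this exchange gives a step that can be read: in this assay, trifluoromethyl in place of methyl on the aromatic carbon gives a 2.7-fold lower number from compound 1 to compound 4 (0.43 log units; beyond the scatter), a modest but real change. A lower number here means that the compound disappears faster, so this position of the 3-methylbenzyl group is not a silent one, and the half-life responds to what is placed there, even though the three earlier compounds could hardly be told apart from one another. This single pair shows the size and direction of the change, but the data offer no measurement that explains it.

Going by these compounds, it remains open whether the drop belongs to trifluoromethyl in particular, or whether a chlorine atom, a methoxy group or a nitrile on this same aromatic carbon would also lower the number. On these data alone, it is equally open whether the same exchange would give a step of similar size on the 2-methylphenyl group of compound 3, or on the naphthalen-1-yl group of compound 2.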